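Swapping a sulfonyl group for isopropyl on a dormant core

The source may hold more compounds than are shown below. What is called first, only, known or untested is meant among the compounds shown, and "the series" means these compounds.

Compound 1 has the structure `CC1(C)C(=O)N(c2ccc(S(C)(=O)=O)cc2)c2ncccc21`. In a functional assay on the whole organism (Pleural cavity) for inhibition, with Rattus norvegicus as the target, at a dose of 25 mg/kg (a lower number here means less inhibition, a higher number more inhibition at the dose given (going by the name of the read-out)), compound 1 gives 0%, which means that at the dose used no inhibition was seen at all. The only companion measured so far is compound 2, with the structure `CC1(C)C(=O)N(c2ccccc2)c2ncc(Br)cc21`, and in this assay compound 2 gives 0%, so compound 1 stands level with compound 2 at the digits reported, and the two lie within the usual scatter of each other; neither number can be called higher or lower than the other.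

Compound 3, with the structure `CC(C)c1ccc(N2C(=O)C(C)(C)c3cccnc32)cc1`, has not yet been measured. It differs from compound 1 at one spot: isopropyl in place of methylsulfonyl on an aromatic carbon. Within the data shown here, no measured pair shows what such a change does on this core.

With both measured compounds showing no inhibition, the expectation is that the change from compound 1 to compound 3 brings no step beyond the scatter, and the step of a number 5 percentage points higher from compound 1 to compound 3 (within the scatter) is accordingly estimated as small. Compound 3 is expected to give about 5% in this assay, within a range from 0% to 25%.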

Compound 3, a percentage reported as inhibition, in the whole organism at one dose (the size of the read-out at that dose, not a potency): 6%
The estimate for compound 3 lay 1 percentage points below the measured number; low and high end bracket the measured number.
By their numbers in this assay, from the lowest: compounds 1, 2 and 3 (each within the scatter of the next).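

Among these compounds, the pair of compound 1 and compound 3 is the first direct test of this position, the aromatic carbon para to a large group. In this assay, putting isopropyl in place of methylsulfonyl gives a number 6 percentage points higher from compound 1 to compound 3 (within the scatter), so the read-out does not separate the two compounds. The exchange is a substantial one on paper, since a group of carbon, oxygen and sulfur with 2 hydrogen-bond acceptors gives way to an all-carbon group with 0 hydrogen-bond acceptors, yet this single-dose whole-animal read-out shows no difference beyond the scatter, and no measurement shown here bears on why that is so.

What the shared core can do with other groups at this position remains open: an amine, a carboxylic acid or a longer carbon chain might or might not bring inhibition clearly beyond the scatter of these compounds. Also open, as far as these compounds go, is whether compound 1 and compound 3 would differ at another dose, as a single dose gives the size of the effect at that dose and says nothing about potency.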